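The compounds below may be only part of what the source reports. "The series", "measured", "known", "first", "only" and "open" are said of these compounds alone.

Of the compounds shown here, three that share one core have been tested in an ADME assay on CEM-SS cells (Homo sapiens) for cytotoxicity, read by XTT assay, with a stated time of 6 days; on this read-out lower numbers stand for higher toxicity in this test and higher numbers for lower toxicity in this test. Among the compounds with values here, compound 2, `CCCC(=O)OCSc1ccccc1C(=O)NCC(=O)OC`, is the only one with a full number: in this assay compound 2 gives 27.3 uM. Compound 1, `CCCC(=O)OCSc1ccccc1C(=O)NCC(N)=O`, reaches only a limit of the assay, giving > 100 uM in this assay. Compound 3, `CCCC(=O)OCSc1ccccc1C(=O)NCC(=O)NCC(=O)OC`, likewise reaches only a limit, giving > 100 uM in this assay.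

The difference between compound 2 and compound 1 is amino in place of methoxy on a carbonyl carbon, and it brought an at least 3.6-fold higher number from compound 2 to compound 1 (0.56 log units; beyond the scatter). The cores of compound 2 and compound 3 differ by ((methoxycarbonyl)methyl)amino in place of methoxy on a carbonyl carbon, with an at least 3.6-fold higher number from compound 2 to compound 3 (0.56 log units; beyond the scatter). Between compound 1 and compound 3 the step is a step that the two limits leave unreadable from compound 1 to compound 3 because of the limit of > 100 uM in this assay, at which 2 of the 3 values shown sit.

Compound 4, `CCCC(=O)OCSc1ccccc1C(=O)NCC(=O)NCC(N)=O`, has not yet been measured in this assay. Within the data shown here, it differs from compound 3 by amino in place of methoxy on a carbonyl carbon, and this is the same change as the one from compound 2 to compound 1, made at the same kind of place. That earlier change moved the number upward and out of the readable range, and compound 3 already sits at the limit, so compound 4 is expected to stay there as well, an expected step that the limit leaves unreadable from compound 3 to compound 4 resting on an at least 3.6-fold higher number from compound 2 to compound 1 (0.56 log units; beyond the scatter) and on the limit at which compound 3 gives > 100 uM. The estimate for compound 4 in this assay is therefore 150 uM, with a range from 80 uM to 400 uM.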

Compound 4, half-maximal toxic concentration: > 100 uM
Compound 4 gave a limit, no number; the forecaster's own chance of this, stated with the estimate: 85%; the middle value lies beyond the limit too.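

In this assay compound 4 gives > 100 uM, which is a limit of the assay and not a number. Within the data shown here, the one new step that can be read is an at least 3.6-fold higher number from compound 2 to compound 4 (0.56 log units; beyond the scatter), and it points the same way as an at least 3.6-fold higher number from compound 2 to compound 1 (0.56 log units; beyond the scatter), so nothing here goes against carrying amino in place of methoxy on a carbonyl carbon from the core of compound 2 over to the core of compound 3. This is no proof that the change carries over, however: its effect on the core of compound 3 cannot be read, and neither can the step between compound 1 and compound 4, because compound 1, compound 3 and compound 4 all end at the same limit: the limit of > 100 uM in this assay, at which 3 of the 4 values shown sit.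

The compounds shown leave open how far beyond the limit compound 1, compound 3 and compound 4 really lie, and so whether the change has an effect of similar size on both cores. They also leave open what a carboxylic acid or a methylamino group would give on the same carbonyl carbon, in place of the methoxy of compound 2 or compound 3.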